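One Methyl, Two Cores: Expecting Compound 4

The source may hold more compounds than are shown below. What is called first, only, known or untested is meant among the compounds shown, and "the series" means these compounds.

Compound 1 `COc1cc(-c2cc(COCc3cn(Cc4cc(-c5ccccc5)cnc4Cl)nn3)on2)cc(OC)c1OC` and compound 2 `COc1cc(-c2cc(COCc3cn(Cc4cc(-c5ccc(C)cc5)cnc4Cl)nn3)on2)cc(OC)c1OC` share one core; compound 3 `COc1cc(C2=NOC(COCc3cn(Cc4cc(-c5ccccc5)cnc4Cl)nn3)C2)cc(OC)c1OC` and compound 4 `COc1cc(C2=NOC(COCc3cn(Cc4cc(-c5ccc(C)cc5)cnc4Cl)nn3)C2)cc(OC)c1OC` share another, and the difference between the two cores is not broken down here. In a functional assay on A549 cells (Homo sapiens) for cytotoxicity, read by MTT assay, with a stated time of 48 h (a higher number here means a weaker inhibitor, a lower number a stronger inhibitor), compound 1 gives 112000 nM, compound 2 gives 30600 nM, and compound 3 gives 8600 nM, the lowest of the three. The change from compound 1 to compound 2 is methyl in place of hydrogen on an aromatic carbon. That step gave a 3.7-fold lower number from compound 1 to compound 2 (0.56 log units; beyond the scatter). The change from compound 3 to compound 4 is methyl in place of hydrogen on an aromatic carbon, the same change at the same place. Among the measured compounds shown here, a step of similar size is expected here, a 3.0-fold lower number from compound 3 to compound 4 (0.47 log units; beyond the scatter), resting on the single measured step of a 3.7-fold lower number from compound 1 to compound 2 (0.56 log units; beyond the scatter) and on nothing more. Compound 4 is therefore estimated at 2900 nM, expected to fall between 1200 nM and 7000 nM.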

Compound 4, half-maximal inhibitory concentration: 11500 nM
The estimate for compound 4 lay 4.0-fold (0.60 log units) below the measured number; measured number above the stated range.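

In this assay, the same swap of phenyl to 4-methylphenyl on the second core gives a 1.3-fold higher number from compound 3 to compound 4 (0.13 log units; within the scatter), so no effect of the methyl can be seen there. The step measured on one core therefore did not carry over to the other: the same change on two cores in this assay, a 3.7-fold lower number (0.56 log units; beyond the scatter) from compound 1 to compound 2 and a 1.3-fold higher number (0.13 log units; within the scatter) from compound 3 to compound 4, 4.9-fold (0.69 log units) apart, beyond the scatter of two such steps This rests on a single pair on each core, so it shows that the step cannot be assumed to transfer between these cores, but it does not show why the two results differ or how other changes would behave.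

The compounds shown leave open whether an ethyl group or a fluorine atom in place of that methyl would also give different steps on the two cores.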